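Chloro in Place of Methyl: Expectation for Compound 4

The compounds below may be only part of what the source reports. "The series", "measured", "known", "first", "only" and "open" are said of these compounds alone.

Three compounds share one core and differ only in the aromatic ring on the carbon with a double bond to nitrogen. Compound 1 `CCOC(=O)c1c(N)sc(/N=C/c2ccccc2)c1C(=O)OCC` gives 30300 nM in a functional assay on T47D cells (Homo sapiens) for inhibition, read by MTT assay, with a stated time of 48 h; a lower number here means a stronger inhibitor, a higher number a weaker inhibitor. Compound 2 `CCOC(=O)c1c(N)sc(/N=C/c2ccncc2)c1C(=O)OCC` gives 8600 nM in this assay, and compound 3 `CCOC(=O)c1c(N)sc(/N=C/c2ccc(C)cc2)c1C(=O)OCC` gives 37200 nM, the highest of the three numbers, though its gap to compound 1 is within the scatter. The step of a 1.2-fold higher number from compound 1 to compound 3 (0.09 log units; within the scatter) lies within the scatter, while a 4.3-fold higher number from compound 2 to compound 3 (0.64 log units; beyond the scatter) is modest. Compound 4 `CCOC(=O)c1c(N)sc(/N=C/c2ccc(Cl)cc2)c1C(=O)OCC` differs from compound 3 by chloro in place of methyl on an aromatic carbon. Among the compounds with values here, no measured step exchanges chloro for methyl, so no close precedent exists; the nearest comparison, a 1.2-fold higher number from compound 1 to compound 3 (0.09 log units; within the scatter), barely moved the number. A step within the scatter is therefore expected, a 1.2-fold lower number from compound 3 to compound 4 (0.09 log units; within the scatter). Compound 4 is estimated at 30000 nM, ranging from 10000 nM to 90000 nM.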

Compound 4, half-maximal inhibitory concentration: 12100 nM
For compound 4 the middle estimate is 2.5-fold (0.39 log units) above the measured one; low and high end bracket the measured number.
By their numbers in this assay, from the lowest: compounds 2 and 4 (each within the scatter of the next); then compounds 1 and 3 (each within the scatter of the next).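

Two groups of one heavy atom each are not interchangeable at this position: a 3.1-fold lower number from compound 3 to compound 4 (0.49 log units; beyond the scatter) is a real change, although methyl in place of hydrogen had left the number within the scatter. Chloro in place of hydrogen also counts, giving a 2.5-fold lower number from compound 1 to compound 4 (0.40 log units; beyond the scatter) as a second step beyond the scatter, while a 1.4-fold higher number from compound 2 to compound 4 (0.15 log units; within the scatter) leaves 4-chlorophenyl and pyridin-4-yl within the scatter of each other. Nothing available gives a reason for the gap between chloro and methyl. From the compounds shown here alone, whether fluoro, bromo or an amine on this aromatic carbon would behave like chloro or like methyl stays open.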